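Para-methyl swap on a bromo core, expected outcome

The source may hold more compounds than are shown below. What is called first, only, known or untested is meant among the compounds shown, and "the series" means these compounds.

Compound 1 `Cc1cccc(/C=C/C(=O)Nc2ccc(Cl)cc2C(N)=O)c1` and compound 2 `Cc1ccc(/C=C/C(=O)Nc2ccc(Cl)cc2C(N)=O)cc1` share one core and differ only as set out in 4-methylphenyl in place of 3-methylphenyl on a double-bonded chain carbon bound to a double-bonded chain carbon. In a functional assay on K562 cells (Homo sapiens) for inhibition, read by trypan blue exclusion, with a stated time of 48 h (on this read-out higher numbers stand for weaker inhibition and lower numbers for stronger inhibition), compound 1 reaches only a limit of the assay, > 10000 nM. In this assay compound 2 gives 6300 nM. The step is an at least 1.5-fold lower number from compound 1 to compound 2 (0.20 log units; that floor lies within the scatter), and its size cannot be pinned down because the limit of > 10000 nM in this assay, at which 2 of the 3 values shown sit, fixes one end of it.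

Compound 3 `Cc1cccc(/C=C/C(=O)Nc2ccc(Br)cc2C(N)=O)c1` carries the core change described in bromo in place of chloro on an aromatic carbon. In this assay compound 3 also returns a limit of the assay, > 10000 nM. The step between the two cores is therefore a step that the two limits leave unreadable from compound 1 to compound 3, and nothing in the three values separates the chloro core from the bromo core.

Compound 4 `Cc1ccc(/C=C/C(=O)Nc2ccc(Br)cc2C(N)=O)cc1` is the not yet measured partner of compound 3. The change from compound 3 to compound 4 is 4-methylphenyl in place of 3-methylphenyl on a double-bonded chain carbon bound to a double-bonded chain carbon, the same change as that from compound 1 to compound 2, made on the same place and against the bromo core instead of the chloro core. The expectation is that the step repeats in direction, with the size estimated as an at least 1.4-fold lower number from compound 3 to compound 4 (0.15 log units; that floor lies within the scatter), resting on compound 2 and its value 6300 nM. Compound 1 itself returned only a limit of the assay, so the size of that earlier step is open at one end. For compound 4 in this assay the estimate is 7000 nM, with an expected range from 3000 nM to 20000 nM, and a real chance that only a limit is returned.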

Compound 4, half-maximal inhibitory concentration: > 10000 nM
Compound 4 gave a limit, no number; the forecaster's own chance of this, stated with the estimate: 40%; middle value at least 1.4-fold (0.15 log units) from the limit.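

In this assay compound 4 returns only a limit of the assay, > 10000 nM. With the 4-methylphenyl group held constant, bromo in place of chloro gives an at least 1.5-fold higher number from compound 2 to compound 4 (0.20 log units; that floor lies within the scatter), so the printed floor does not establish a difference between the two cores. The result neither confirms nor contradicts the transfer of 4-methylphenyl in place of 3-methylphenyl from the chloro core to the bromo core, and the steps from compound 1 to compound 3 and from compound 3 to compound 4 cannot be read, because three of the four compounds stop at the same boundary: the limit of > 10000 nM in this assay, at which 3 of the 4 values shown sit.

From the compounds shown here alone, only compound 2 gives a number, so the size of the methyl shift remains open on both cores, as does any difference between the chloro and bromo cores. Also open, going by these compounds, is whether an amine, a carboxylic acid or a longer chain in place of the methyl group on the 4-methylphenyl ring would give a measured value on either core, which would allow the comparison between cores to be read as a number rather than against a limit.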